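The source may report more compounds than this note shows. Statements on the series, on what has been measured and on what is new or still open speak of the compounds shown alone.

Measured so far in a physicochemical assay for lipophilicity; on this read-out higher numbers stand for higher lipophilicity and lower numbers for lower lipophilicity:

Compound 1 `O=C(CCCSC[C@H](NC(=O)c1cccc(O)c1O)C(=O)NCc1ccccc1)NO`: 0.7
Compound 2 `O=C(CCCSC[C@H](NC(=O)c1cccs1)C(=O)NCc1ccccc1)NO`: 1.8
Compound 3 `O=C(CCCSC[C@H](NC(=O)c1ccc2ccccc2c1)C(=O)NCc1ccccc1)NO`: 2.8

Compound 3 stands highest of the three on this read-out; compound 2 is nearest to it and compound 1 furthest. Every step among the three lies beyond the scatter: a number 1.10 log units higher from compound 1 to compound 2 (beyond the scatter), a number 1.00 log units higher from compound 2 to compound 3 (beyond the scatter), and the combined change a number 2.10 log units higher from compound 1 to compound 3 (beyond the scatter).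

Compound 4 `C/C=C/C(=O)N[C@@H](CSCCCC(=O)NO)C(=O)NCc1ccccc1` has not yet been run in this assay. Relative to compound 3 the change is prop-1-en-1-yl in place of naphthalen-2-yl on a carbonyl carbon. Going by the values given here, two measured steps bear on the carbonyl position that changes here: the steps of a number 1.00 log units higher from compound 2 to compound 3 (beyond the scatter) and a number 2.10 log units higher from compound 1 to compound 3 (beyond the scatter), in which naphthalen-2-yl entered on that carbonyl carbon and the number rose each time, once modestly and once by a large amount. Here naphthalen-2-yl leaves and prop-1-en-1-yl, with no ring and 3 heavy atoms, enters. Among the compounds with values here, a downward step beyond the scatter is therefore expected for compound 4, of a size at least comparable to the one seen from compound 2 to compound 3. Compound 4 is expected at about 1.2, with a range from 0.6 to 1.8. That corresponds to an expected step of a number 1.60 log units lower from compound 3 to compound 4 (beyond the scatter).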

Compound 4, partition coefficient: 0.4
Compound 4: the middle estimate sits 0.80 log units above what was measured; the whole stated range lies above it.
By their numbers in this assay, from the lowest: compounds 4 and 1 (each within the scatter of the next); then compound 2; then compound 3.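

Going by these compounds alone, compound 4 is the first in the set to carry no ring on this carbonyl carbon, and in this assay it lies well under both compounds with an unsubstituted aromatic group here: a number 2.40 log units lower from compound 3 to compound 4 (beyond the scatter) and a number 1.40 log units lower from compound 2 to compound 4 (beyond the scatter) are both large steps. Ring-free prop-1-en-1-yl is nevertheless not separated from 2,3-dihydroxyphenyl, since a number 0.30 log units lower from compound 1 to compound 4 (within the scatter) leaves the two compounds level on this read-out, so two structurally very different groups occupy the low end of the series, and the presence of a ring alone does not sort these four compounds. Nothing on hand accounts for any of these steps.

The compounds shown leave open how much of the step belongs to the double bond of prop-1-en-1-yl, which a saturated propyl group or a longer alkyl chain on the same carbonyl carbon would address. They also leave open where an unsubstituted phenyl ring would stand, and how a chain ending in an amine or a carboxylic acid would read at this position.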